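From Phenyl to 4-Methylbenzyl on the Amide Nitrogen

A few compounds are considered here, and "the series" means these few. Any claim that something is new, unique, unknown or untested is made for them only; others in the source may bear on it.

Compound 1 `COc1cc([C@@H]2C[C@@]2(CO)C(=O)Nc2ccccc2)cc(OC)c1OC`: 36700 nM
Compound 2 `COc1cc([C@H]2C[C@@]2(CO)C(=O)Nc2ccccc2)cc(OC)c1OC`: > 100000 nM
Compound 3 `CCOC(=O)C1(C(=O)Nc2ccccc2Cl)CC1c1cc(OC)c(OC)c(OC)c1`: 36100 nM; 48800 nM (2 entries)
Compound 4 `COc1cc([C@@H]2C[C@@]2(CO)C(=O)NCc2ccc(C)cc2)cc(OC)c1OC`: not yet measured

Among the measured compounds shown here, in a functional assay on QGY cells (Homo sapiens) for cytotoxicity, read by MTT assay, with a stated time of 48 h (on this read-out higher numbers stand for weaker inhibition and lower numbers for stronger inhibition), compound 1 gives 36700 nM, the only compound here with a single number. Compound 2 has only a limit, > 100000 nM. Compound 3 has two separate entries.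

The change to compound 4 is 4-methylbenzyl in place of phenyl on an amide-type nitrogen. For the measured compounds named here, the one measured step is an at least 2.7-fold higher number from compound 1 to compound 2 (0.43 log units; beyond the scatter). It reflects (the fact that compounds 1 and 2 differ only in the configuration as drawn), so it does not test the amide nitrogen, and no direction can be argued from it. The expected step, estimated with little confidence, is a 1.1-fold higher number from compound 1 to compound 4 (0.04 log units; within the scatter), so no change beyond the scatter is expected in this assay. Compound 4 is expected at 40000 nM, with an estimated range of 12000 nM to 100000 nM.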

Compound 4, half-maximal inhibitory concentration: 58700 nM
The estimate for compound 4 lay 1.5-fold (0.17 log units) below the measured number; measured number inside the range.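

Among the compounds shown here, the swap on the amide nitrogen gives the first reading at this position. In this assay it amounts to a 1.6-fold higher number from compound 1 to compound 4 (0.20 log units; within the scatter). So 4-methylbenzyl and phenyl cannot be told apart here, something the earlier step, which changed only the configuration, could not show.

Plain benzyl would be needed to separate the part played by the methyl group from that of the added carbon on the nitrogen. Going by these compounds, whether an amine, a carboxylic acid or a longer chain on this nitrogen would move the number beyond the scatter remains open.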